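The source may report more compounds than this note shows. Statements on the series, on what has been measured and on what is new or still open speak of the compounds shown alone.

Compound 1 `CC(=O)n1nc(C)c(-c2ccc(Cl)c(Cl)c2)c1N` is the starting point here: in an assay on Sf9 cells for inhibition of mitogen-activated protein kinase kinase kinase 14 (Homo sapiens), read by ADP-Glo, with a stated time of 60 min (a higher number here means a weaker inhibitor, a lower number a stronger inhibitor), compound 1 gives 8400 nM. Compound 2 `CCCC(=O)n1nc(C)c(-c2ccc(Cl)c(Cl)c2)c1N` differs from it in a single spot, an ethyl in place of hydrogen on a saturated chain carbon bound to a carbonyl carbon. In this assay compound 2 reaches no number at all, only the limit > 100000 nM. The step from compound 1 to compound 2 is therefore an at least 11-fold higher number from compound 1 to compound 2 (1.07 log units; beyond the scatter), and compound 2 sits at the limit of > 100000 nM in this assay, at which 1 of the 2 values shown sits, so it is only known to be at least that weak.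

Compound 3 `Cc1nn(C(=O)C2CC2)c(N)c1-c1ccc(Cl)c(Cl)c1` is the next variation, with cyclopropyl in place of propyl on a carbonyl carbon. Among the measured compounds shown here, the one measured step that bears on it is the growth of the chain on the carbonyl, which cost potency. Cyclopropyl keeps the same count of carbons as propyl, so the expected step of a number no higher from compound 2 to compound 3 (the limit leaves the size open) is none beyond the scatter. Compound 3 is thus estimated at 100000 nM, within 30000 nM to 300000 nM, and may well land at the limit again.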

Compound 3, half-maximal inhibitory concentration: 24300 nM
Beside the measured number, compound 3's estimate is 4.1-fold (0.61 log units) above it, outside the stated range (below it).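

Swapping propyl for cyclopropyl on the carbonyl carbon keeps the same count of carbon atoms yet gives an at least 4.1-fold lower number from compound 2 to compound 3 (0.61 log units; beyond the scatter), so that count alone does not settle the result at this position. This size is only a minimum, because compound 2 has a limit and not a number: the limit of > 100000 nM in this assay, at which 1 of the 3 values shown sits.

Cyclopropyl in place of methyl on the carbonyl carbon still gives a 2.9-fold higher number from compound 1 to compound 3 (0.46 log units; beyond the scatter), which leaves methyl ahead of both other groups.

On these data alone, it remains open whether an isopropyl, a cyclobutyl or a phenyl on the carbonyl carbon would behave more like cyclopropyl or like propyl. As far as these compounds go, it also remains open whether an amine on that carbon could match or pass compound 1.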